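Side-Chain Swap in a Series Without Measurable Cytotoxicity

The compounds below may be only part of what the source reports. "The series", "measured", "known", "first", "only" and "open" are said of these compounds alone.

Compound 3 `C#CCSc1nnc(-c2cc(OC)c(OC)c(OC)c2)n1N1C(=O)c2ccccc2C1=O` was tested in a functional assay on HepG2 cells (Homo sapiens) for cytotoxicity, read by MTT assay, with a stated time of 48 h (a higher number here means a weaker inhibitor, a lower number a stronger inhibitor), and compound 3 gives only a limit there, > 200000 nM. Its two companions behave alike. Compound 2 `COc1cc(-c2nnc(SCc3ccccc3Cl)n2N2C(=O)c3ccccc3C2=O)cc(OC)c1OC` gives a limit of > 200000 nM. Compound 1 `CCc1nnc(SCC(=O)c2ccc(Cl)cc2)n1N1C(=O)c2ccccc2C1=O` gives a limit of > 200000 nM. For the measured compounds named here, compound 3 therefore stands at exactly the same point as everything else: every value shown is a limit, as the limit of > 200000 nM in this assay, at which 3 of the 3 values shown sit, records, so no compound can be called stronger or weaker than another.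

Going by the values given here, the one single-place step among the measured compounds, a step that the two limits leave unreadable from compound 2 to compound 3, is unreadable, since both of its ends are limits and its size cannot be read.

Compound 4 `COc1cc(-c2nnc(SCC(=O)c3ccc(Cl)cc3)n2N2C(=O)c3ccccc3C2=O)cc(OC)c1OC` differs from compound 3 in one place: (4-chlorophenyl)carbonyl in place of ethynyl on a saturated chain carbon bound to a sulfur. Compound 1 carries the same (4-chlorophenyl)carbonyl on a saturated chain carbon bound to a sulfur, attached to a different core. Compound 1 also shows only a limit. Among the compounds with values here, no measured step bears on this change with a readable size, so no step beyond the scatter is expected in this assay in either direction. Compound 4 is expected to remain at the limit, the expected step being a number no higher from compound 3 to compound 4 (the limit leaves the size open). The estimate for compound 4 in this assay is 200000 nM, between 50000 nM and 1000000 nM.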

Compound 4, half-maximal inhibitory concentration: 22000 nM
The estimate for compound 4 lay 9.1-fold (0.96 log units) above the measured number; measured number outside the range, below it.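

In this assay, the (4-chlorophenyl)carbonyl on a saturated chain carbon bound to a sulfur gives this series its first readable steps: there is an at least 9.0-fold lower number from compound 3 to compound 4 (0.95 log units; beyond the scatter) where it replaces ethynyl, and there is an at least 9.0-fold lower number from compound 2 to compound 4 (0.95 log units; beyond the scatter) where it replaces 2-chlorophenyl. The group is not enough by itself, since compound 1 carries it and still gives only a limit, and the other side of the molecule also counts: there is an at least 9.0-fold lower number from compound 1 to compound 4 (0.95 log units; beyond the scatter) with 3,4,5-trimethoxyphenyl in place of ethyl on an aromatic carbon. Only compound 4 holds both groups, while compounds 1, 2 and 3 each hold just one of them and all stay at the limit of the series: the limit of > 200000 nM in this assay, at which 3 of the 4 values shown sit.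

Going by these compounds, each of these steps has a limit at one end, so its full size remains unknown. Also open, on these data alone, is whether the carbonyl or the chlorine matters more for the step, and what a carboxylic acid or an amine would do on the same saturated chain carbon.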